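The source may report more compounds than this note shows. Statements on the series, on what has been measured and on what is new or still open speak of the compounds shown alone.

In an assay on membranes from striatum (strain Sprague-Dawley) for displacement of a labelled ligand from sodium-dependent dopamine transporter (Rattus norvegicus), read by scintillation counting, with a stated time of 120 min (a lower number here means a stronger inhibitor, a higher number a weaker inhibitor), three compounds have been measured so far:

Compound 3 `O=C(c1ccccc1)N1CCC(NCCSC(c2ccc(F)cc2)c2ccc(F)cc2)CC1`: 4.51 nM
Compound 1 `[O-][S+](CCNC1CCN(Cc2ccc(F)cc2)CC1)C(c1ccc(F)cc1)c1ccc(F)cc1`: 50.6 nM
Compound 2 `[O-][S+](CCNC1CCN(CC(O)Cc2ccccc2)CC1)C(c1ccc(F)cc1)c1ccc(F)cc1`: 91.8 nM

Compound 3 has the lowest number of the three. Compound 1 comes nearest to it and compound 2 lies furthest away, and both of those gaps are beyond the scatter, so compound 3 is the strongest inhibitor among the measured compounds. For the measured compounds named here, the only step measured between neighbouring compounds is a 1.8-fold higher number from compound 1 to compound 2 (0.26 log units; within the scatter), a change on the ring nitrogen of a differently built pair; it stays within the scatter and does not touch a carbonyl, so it offers no direct guide to the change at hand.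

Compound 4 `CC(C)(C)C(=O)N1CCC(NCCSC(c2ccc(F)cc2)c2ccc(F)cc2)CC1` differs from compound 3 by tert-butyl in place of phenyl on a carbonyl carbon. No measured step covers a change of this kind, so the expectation rests on the absence of evidence for a large effect rather than on a shown trend. In this assay, compound 4 is expected to show a 2.2-fold higher number from compound 3 to compound 4 (0.35 log units; beyond the scatter), a modest move toward a higher number at most. Compound 4 is therefore estimated at 10 nM, with a range from 3 nM to 40 nM.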

Compound 4, inhibition constant: 352 nM
For compound 4 the middle estimate is 35-fold (1.55 log units) below the measured one, and the stated range ends below it.
By their numbers in this assay, from the lowest: compound 3; then compounds 1 and 2 (each within the scatter of the next); then compound 4.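

In this assay the group on this carbonyl carbon matters a great deal: tert-butyl in place of phenyl brings a 78-fold higher number from compound 3 to compound 4 (1.89 log units; beyond the scatter) in a single change. For the compounds shown here, the earlier compounds offered only a step within the scatter at a different place, so this is the first sign that the number responds strongly to what sits on the carbonyl carbon. It also shows that this swap, from a six-membered aromatic ring to a smaller group with no ring, is far from neutral, though nothing measured here accounts for the size of the step.

As far as these compounds go, what stays open is whether a ring as such is what counts here: cyclohexyl on the same carbonyl carbon would separate a ring from an aromatic ring. A pyridyl group or a small methyl group at this place would show how narrow the tolerance is.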